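This account rests on a few compounds, and the source may have more. Where it says the series, first, only, none or still open, it means among the compounds named here.

Measured in a physicochemical assay for solubility, read by nephelometry, measured as kinetic solubility, with a stated time of 30 min; on this read-out lower numbers stand for lower solubility and higher numbers for higher solubility:
- compound 1 `CC(C)(O)CNCCCOc1ccc([C@H]2CC[C@]3(CC2)OOC2(O3)C3CC4CC(C3)CC2C4)cc1`: > 100 ug/mL
- compound 2 `CC(C)(CN)Oc1ccc([C@H]2CC[C@]3(CC2)OOC2(O3)C3CC4CC(C3)CC2C4)cc1`: > 100 ug/mL
- compound 3 `CC1(C)CC(O)(COc2ccc([C@H]3CC[C@]4(CC3)OOC3(O4)C4CC5CC(C4)CC3C5)cc2)CC(C)(C)N1`: > 100 ug/mL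

Compound 3 gives > 100 ug/mL, which is a limit and not a number. All three compounds share the same mark, (the limit of > 100 ug/mL in this assay, at which 3 of the 3 values shown sit).

The next compound is compound 4 `O[C@H]1CC[C@H](NCCCOc2ccc([C@H]3CC[C@]4(CC3)OOC3(O4)C4CC5CC(C4)CC3C5)cc2)CC1`. The change is 2-((4-hydroxycyclohexyl)amino)ethyl in place of 4-hydroxy-2,2,6,6-tetramethylpiperidin-4-yl on a saturated chain carbon bound to an oxygen on an aromatic ring. In words, it is 2-((4-hydroxycyclohexyl)amino)ethyl in place of 4-hydroxy-2,2,6,6-tetramethylpiperidin-4-yl on a saturated chain carbon bound to an oxygen on an aromatic ring.

The closest measured comparison is a step that the two limits leave unreadable from compound 1 to compound 3, made at the same place. Also relevant is a step that the two limits leave unreadable from compound 2 to compound 3. Neither gives a size that can be carried over. Compound 1 has a closely similar aminoalkyl chain and reads > 100 ug/mL, a limit, so a result near that limit is expected for compound 4. No change beyond the usual scatter is expected in this assay, and the expected step is a number no higher from compound 3 to compound 4 (the limit leaves the size open). The estimate for compound 4 is 100 ug/mL, with an expected range from 50 ug/mL to 200 ug/mL.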

Compound 4, solubility: > 100 ug/mL
Compound 4 gave a limit, no number; the forecaster's own chance of this, stated with the estimate: 75%; the middle value sits exactly at the limit.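

In this assay compound 4 gives > 100 ug/mL, which is a limit and not a number, so no new step can be read between compound 4 and compound 1, compound 2 or compound 3: the limit of > 100 ug/mL in this assay, at which 4 of the 4 values shown sit. The compounds shown leave open how their solubilities compare, and whether any of these changes alters the read-out at all.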